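The source may hold more compounds than are shown below. What is called first, only, known or untested is meant among the compounds shown, and "the series" means these compounds.

Measured in a functional assay on HT-29 cells (Homo sapiens) for inhibition, read by luminescence and CellTiter-Glo, with a stated time of 24 h; a higher number here means that more compound is needed for the effect, a lower number that less compound is needed:
Compound 1 `CC(C)Cn1nc(C(=O)N[C@H]2COc3ccccc3N(C)C2=S)nc1Cc1ccccc1`: 1230 nM
Compound 2 `CN1C(=S)[C@@H](NC(=O)c2nc(Cc3ccccc3)n(CCCF)n2)COc2ccccc21`: 4760 nM

Of these two compounds, compound 2 has the higher number, so more of it is needed for the effect. For the measured compounds named here, the gap to its only neighbour is a 3.9-fold higher number from compound 1 to compound 2 (0.59 log units; beyond the scatter), and this step lies beyond the scatter.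

Compound 3 `CN1C(=S)[C@@H](NC(=O)c2nc(Cc3ccccc3)n(CCC(F)(F)F)n2)COc2ccccc21` keeps the core of compound 2 and alters only the end of the chain. Trifluoromethyl stands in place of fluoromethyl on a saturated chain carbon, two bonds along the chain from an aromatic nitrogen, turning 3-fluoropropyl into 3,3,3-trifluoropropyl: trifluoromethyl in place of fluoromethyl on a saturated chain carbon, two bonds along the chain from an aromatic nitrogen.

Going by the values given here, no measured step makes this exact change. Among the compounds with values here, the one step that bears on it, at the same chain, is the modest 3.9-fold higher number from compound 1 to compound 2 (0.59 log units; beyond the scatter), which shows that the number responds to changes there. A step of similar or smaller size is therefore expected, leaning tentatively towards a lower number, though the direction rests on little evidence.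

The expected change is a 1.7-fold lower number from compound 2 to compound 3 (0.23 log units; within the scatter). For compound 3 the estimated value is 2800 nM, with an expected range from 1000 nM to 8000 nM.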

Compound 3, half-maximal effective concentration: 1550 nM
Compound 3: the middle estimate sits 1.8-fold (0.26 log units) above what was measured; the measured number falls inside the stated range.
By their numbers in this assay, from the lowest: compounds 1 and 3 (each within the scatter of the next); then compound 2.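

In this assay, the step of a 3.1-fold lower number from compound 2 to compound 3 (0.49 log units; beyond the scatter) shows that the end of this chain matters by itself: with the propyl chain kept, trifluoromethyl in place of fluoromethyl, two bonds along the chain from an aromatic nitrogen, moves the number beyond the scatter and towards less compound being needed, a direction that the earlier pair, which changed the whole chain, could not show. The 3,3,3-trifluoropropyl chain also leaves compound 3 level with compound 1, the step being a 1.3-fold higher number from compound 1 to compound 3 (0.10 log units; within the scatter) and so within the scatter, which means that among these three compounds only the 3-fluoropropyl chain of compound 2 stands apart. Nothing available here explains why the change at the end of the chain has this result.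

As far as these compounds go, it remains open whether difluoromethyl at the same place would side with fluoromethyl or with trifluoromethyl. From the compounds shown here alone, it is also open whether an amine or a carboxylic acid at the end of this chain, or a longer chain ending in trifluoromethyl, would keep the number at the level of compound 3.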